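Quinoline amide series: trifluoromethyl replacing ethoxy at the aryl position

The source may hold more compounds than are shown below. What is called first, only, known or untested is meant among the compounds shown, and "the series" means these compounds.

Of the compounds shown here, two have been measured in a functional assay on A-375 cells (Homo sapiens) for antiproliferative activity, read by MTT assay, with a stated time of 24 h, tested at 3.7 ug/mL; on this read-out lower numbers stand for a weaker effect and higher numbers for a stronger effect at the one concentration tested. Compound 1 `CCc1ccc2nc(C(=O)Nc3c(F)cc(-c4cccc(F)c4)cc3F)c(C)c(C(=O)O)c2c1` carries an ethyl group on the fused carbocyclic ring and in this assay compound 1 gives 26.7%. Compound 2 `CCOc1ccc2nc(C(=O)Nc3c(F)cc(-c4cccc(F)c4)cc3F)c(C)c(C(=O)O)c2c1` carries an ethoxy group at the same place and in this assay compound 2 gives 35.2%. Going by the values given here, the only step so far, a number 8.5 percentage points higher from compound 1 to compound 2 (within the scatter), does not separate the two compounds. Compound 2 holds the higher of the two numbers, but its distance to compound 1 lies within the scatter, so no ranking can be drawn.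

Compound 3 `Cc1c(C(=O)Nc2c(F)cc(-c3cccc(F)c3)cc2F)nc2ccc(C(F)(F)F)cc2c1C(=O)O` remains to be measured. The change from compound 2 is trifluoromethyl in place of ethoxy on an aromatic carbon. Among the compounds with values here, no measured step covers a trifluoromethyl group at this position, and the one step available, from an ethyl to an ethoxy group, stayed within the scatter. With only this to go on, a step of comparable size is expected, and the estimated step of a number 4.2 percentage points lower from compound 2 to compound 3 (within the scatter) is taken to be within the scatter. Compound 3 is therefore expected to give about 31% in this assay, with a range from 12% to 52%.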

Compound 3, a percentage reported as inhibition, at one concentration (the size of the read-out at that concentration, not a potency): 27.8%
Beside the measured number, compound 3's estimate is 3.2 percentage points above it; the measured number falls inside the stated range.
By their numbers in this assay, from the lowest: compounds 1, 3 and 2 (each within the scatter of the next).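

In this assay trifluoromethyl in place of ethoxy gives a number 7.4 percentage points lower from compound 2 to compound 3 (within the scatter) and trifluoromethyl in place of ethyl gives a number 1.1 percentage points higher from compound 1 to compound 3 (within the scatter) on the same aromatic carbon. Ethyl, ethoxy and trifluoromethyl at this position therefore all lie within the scatter of one another, so the read-out separates neither the group with a hydrogen-bond acceptor from the two without one nor the group with fluorine from the two without it. No supporting data are available to account for this lack of separation.

Still open, as far as these compounds go, is whether an amine, a carboxylic acid or a longer chain on this aromatic carbon would give a step beyond the scatter, which would show that the position can respond at all in this read-out. Also open, from the compounds shown here alone, is whether the three compounds would stay inseparable in a full concentration series, as a percentage inhibition at one concentration gives no potency and the present numbers cannot rank these groups.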